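Trimming the Carbamate Chain to a Free Amine

The compounds below may be only part of what the source reports. "The series", "measured", "known", "first", "only" and "open" are said of these compounds alone.

Compound 2 `CC(C)(C)OC(=O)NCCCCCNC(=O)CN1CN(c2ccccc2)C2(CCN(C(=O)c3ccc(C(C)(C)C)cc3)CC2)C1=O` carries a protected amine at the end of a chain hanging from the shared core. In an assay on HEK293 cells for displacement of a labelled ligand from NPC1-like intracellular cholesterol transporter 1 (Homo sapiens) (a lower number here means a stronger inhibitor, a higher number a weaker inhibitor), compound 2 gives 13700 nM, the highest of the two numbers measured. Its neighbour compound 1 `CC(C)(C)OC(=O)NCCCNC(=O)CN1CN(c2ccccc2)C2(CCN(C(=O)c3ccc(C(C)(C)C)cc3)CC2)C1=O` differs only in that chain and gives 4500 nM; the move a 3.0-fold higher number from compound 1 to compound 2 (0.48 log units; beyond the scatter) shows that the longer chain weakened binding. Compound 3 `CC(C)(C)c1ccc(C(=O)N2CCC3(CC2)C(=O)N(CC(=O)NCCCN)CN3c2ccccc2)cc1` goes further: amino in place of 2-((tert-butoxycarbonyl)amino)ethyl on a saturated chain carbon, three bonds along the chain from an amide-type nitrogen. Within the data shown here, the step from compound 1 to compound 2 is the only measured one bearing on this, and it covers just the chain length, which in compound 3 returns to that of compound 1; for loss of the carbamate itself no measured pair exists. Because a 3.0-fold higher number from compound 1 to compound 2 (0.48 log units; beyond the scatter) favours the shorter chain, compound 3 is expected to land near compound 1, with the step of a 2.7-fold lower number from compound 2 to compound 3 (0.44 log units; beyond the scatter) estimated as a gain. Compound 3 is therefore estimated at 5000 nM, within 1000 nM to 25000 nM.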

Compound 3, half-maximal inhibitory concentration: 4200 nM
Compound 3: middle estimate off by 1.2-fold (0.08 log units), on the high side, within the range that was stated.
By their numbers in this assay, from the lowest: compounds 3 and 1 (each within the scatter of the next); then compound 2.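

Hydrogen in place of tert-butoxycarbonyl on the amine nitrogen gives a 1.1-fold lower number from compound 1 to compound 3 (0.03 log units; within the scatter), so the carbamate and the free amine cannot be told apart in this assay at this chain length. Among these compounds, this is the first measured view of the end group on its own, since the earlier pair varied only the chain. The larger step, a 3.3-fold lower number from compound 2 to compound 3 (0.51 log units; beyond the scatter), changes both chain length and end group, and with the end group showing no difference on the shorter chain, its size sits close to that of the chain-only step, a 3.0-fold higher number from compound 1 to compound 2 (0.48 log units; beyond the scatter). Nothing measured here explains why these numbers fall as they do.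

Still open, as far as these compounds go, is how a free amine behaves on the longer chain of compound 2, and how a carboxylic acid or a hydroxyl would behave at the chain end.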